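Chloro for fluoro on the five-membered ring of compound 3

The source may report more compounds than this note shows. Statements on the series, on what has been measured and on what is new or still open speak of the compounds shown alone.

Measured compounds:
compound 1 `C#C[C@@]1(O)[C@@H](CO)O[C@@H](n2cnc3c(-c4ccc(C)cc4)ncnc32)[C@@H]1O` — in a functional assay on L1210 cells (Mus musculus) for antiproliferative activity, read by cell counting, with a stated time of 48 h (a higher number here means a weaker inhibitor, a lower number a stronger inhibitor), compound 1 gives 205000 nM
compound 2 `C#C[C@@]1(O)[C@@H](CO)O[C@@H](n2cnc3c(-c4ccc(Cl)cc4)ncnc32)[C@@H]1O` — in this assay compound 2 gives 225000 nM
compound 3 `C#C[C@@]1(O)[C@@H](CO)O[C@@H](n2cc(F)c3c(N)ncnc32)[C@@H]1O` — in this assay compound 3 gives 35 nM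

Compound 3 stands lowest of the three numbers in this assay, far beyond the scatter from both compound 1 and compound 2. Among the measured compounds shown here, it differs from those two in more than one place, so no single step links it to either, and the only counted step among the measured compounds is a 1.1-fold higher number from compound 1 to compound 2 (0.04 log units; within the scatter), which lies within the scatter.

Compound 4 `C#C[C@@]1(O)[C@@H](CO)O[C@@H](n2cc(Cl)c3c(N)ncnc32)[C@@H]1O` is not yet measured. It differs from compound 3 by chloro in place of fluoro on an aromatic carbon.

For the measured compounds named here, the one measured step that bears on this change is the exchange of a halogen for another small group on an aromatic carbon, from compound 1 to compound 2, and it left the number essentially unchanged. That step sits on a different ring and a different core, so it is only a loose guide. On that basis the change from compound 3 to compound 4 is expected to give no step beyond the scatter in this assay, that is a 1.4-fold higher number from compound 3 to compound 4 (0.15 log units; within the scatter). Compound 4 is therefore estimated at 50 nM, with a range from 12 nM to 200 nM.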

Compound 4, half-maximal inhibitory concentration: 14 nM
Beside the measured number, compound 4's estimate is 3.6-fold (0.55 log units) above it, and the stated range covers the measured number.
By their numbers in this assay, from the lowest: compound 4; then compound 3; then compounds 1 and 2 (each within the scatter of the next).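

In this assay putting chloro where fluoro stood, on the five-membered aromatic ring with 1 nitrogen, gives a 2.5-fold lower number from compound 3 to compound 4 (0.40 log units; beyond the scatter) and so shows that this position responds to the exchange of one halogen for another, though the step is modest. The earlier step, a 1.1-fold higher number from compound 1 to compound 2 (0.04 log units; within the scatter) on the core of compound 1, lay within the scatter and showed no response to chloro in place of methyl, so the entry of chloro does not read the same at the two places, which differ in their core as well as in the group that leaves. Nothing given here accounts for the lower number of compound 4, and no measurement beyond the antiproliferative read-out bears on it.

The compounds shown leave open whether bromo, iodo, a nitrile or an amine on this same carbon would give a number lower still than that of compound 4, or a higher one. They also leave open how a plain hydrogen at this place would compare with fluoro and chloro on the shared core.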